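Swapping a Side Group on a Shared Core

The compounds below may be only part of what the source reports. "The series", "measured", "known", "first", "only" and "open" are said of these compounds alone.

In a functional assay on NCI-H460 cells (Homo sapiens) for positive allosteric modulation, read by MTT assay, with stated times of 2 h and 72 h, tested at 3 uM (on this read-out higher numbers stand for weaker inhibition and lower numbers for stronger inhibition), compound 1 (`CCCc1ccc(C(=O)Nc2ccccc2-c2nnn(-c3cccc(OC)c3)n2)cc1`) gives 173 nM and compound 2 (`COc1cccc(-n2nnc(-c3ccccc3NC(=O)c3ccc(NC(=O)CBr)cc3)n2)c1`) gives 175 nM on the same read-out. These two numbers lie within the scatter of each other, so compound 2 stands level with compound 1 and the pair cannot be ranked. Compound 3 (`COc1cccc(-n2nnc(-c3ccccc3NC(=O)Nc3ccc(N)cc3)n2)c1`) has no number yet, and its difference from compound 2 is (4-aminophenyl)amino in place of 4-(((bromomethyl)carbonyl)amino)phenyl on a carbonyl carbon with (4-aminophenyl)amino in place of 4-(((bromomethyl)carbonyl)amino)phenyl on a carbonyl carbon. With only a 1.0-fold higher number from compound 1 to compound 2 (0.00 log units; within the scatter) as a guide, for ((bromomethyl)carbonyl)amino in place of propyl on an aromatic carbon, no step beyond the scatter is expected in this assay for compound 3. That guide concerns a different swap, so the margin stays wide. The estimate is a 1.1-fold higher number from compound 2 to compound 3 (0.06 log units; within the scatter) in either direction. The expected value for compound 3 is 200 nM with a range of 60 nM to 700 nM on this thin evidence.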

Compound 3, half-maximal inhibitory concentration: 216 nM
The estimate for compound 3 lay 1.1-fold (0.03 log units) below the measured number; the measured number falls inside the stated range.
By their numbers in this assay, from the lowest: compounds 1, 2 and 3 (each within the scatter of the next).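

Within the data shown here, until now, the only change seen was on an aromatic carbon of the end ring. Here, the whole piece on the carbonyl carbon is exchanged: in this assay, putting (4-aminophenyl)amino in place of 4-(((bromomethyl)carbonyl)amino)phenyl gives a 1.2-fold higher number from compound 2 to compound 3 (0.09 log units; within the scatter), and putting it in place of 4-propylphenyl gives a 1.2-fold higher number from compound 1 to compound 3 (0.10 log units; within the scatter). All three compounds therefore stand level, so this read-out does not separate a propyl end, a bromine-bearing end and an amino end, even when the atom attached to the carbonyl carbon changes from ring carbon to amide-type nitrogen.

On these data alone, whether a carboxylic acid or a longer carbon chain on that ring would stay level remains open, as does the effect of removing the ring altogether. Nothing available explains why these numbers stay level.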